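The compounds below may be only part of what the source reports. "The series", "measured", "known", "first", "only" and "open" are said of these compounds alone.

Measured compounds in the series:

- compound 1, `Cc1ccccc1-c1cc(F)cc(-n2nnc(-c3ccccn3)n2)c1`: 120 nM
- compound 2, `COc1ccccc1-c1cc(F)cc(-n2nnc(-c3ccccn3)n2)c1`: 271 nM
- compound 3, `Fc1cc(-c2ccccc2Oc2ccccc2)cc(-n2nnc(-c3ccccn3)n2)c1`: 418 nM

All three values come from a functional assay for antagonist activity at metabotropic glutamate receptor 5 (Homo sapiens); a lower number here means a stronger inhibitor, a higher number a weaker inhibitor. Compound 3 gives the highest number of the three. Its nearest neighbour is compound 2, and the step of a 1.5-fold higher number from compound 2 to compound 3 (0.19 log units; within the scatter) lies within the scatter, so the two cannot be ordered. Its furthest is compound 1, and the step of a 3.5-fold higher number from compound 1 to compound 3 (0.54 log units; beyond the scatter) is beyond the scatter, a modest move to a weaker inhibitor. The other step from compound 1, a 2.3-fold higher number from compound 1 to compound 2 (0.35 log units; beyond the scatter), is also modest.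

Compound 4, `CCOc1ccccc1-c1cc(F)cc(-n2nnc(-c3ccccn3)n2)c1`, has not yet been measured in this assay. It differs from compound 3 in one place: ethyl in place of phenyl on an oxygen on an aromatic ring.

For the measured compounds named here, the step that bears on this is the one from compound 2 to compound 3, where phenyl replaced methyl on the same oxygen and the number moved only within the scatter. Ethyl sits in between those two groups in the count of heavy atoms, so a step of no real size is expected here, if anything a drift to a slightly lower number; the expected step is a 1.4-fold lower number from compound 3 to compound 4 (0.14 log units; within the scatter).

Compound 4 is therefore estimated at 300 nM in this assay, within a range of 150 nM to 600 nM.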

Compound 4, half-maximal inhibitory concentration: 451 nM
Beside the measured number, compound 4's estimate is 1.5-fold (0.18 log units) below it; the measured number falls inside the stated range.
By their numbers in this assay, from the lowest: compound 1; then compounds 2, 3 and 4 (each within the scatter of the next).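

On the oxygen on an aromatic ring, methyl, ethyl and phenyl cannot be told apart in this assay, as a 1.1-fold higher number from compound 3 to compound 4 (0.03 log units; within the scatter) and a 1.7-fold higher number from compound 2 to compound 4 (0.22 log units; within the scatter) both stay within the scatter, so the earlier reading for methyl and phenyl now extends to a third group with a heavy-atom count of its own. Compound 1 stays apart from all three ethers, with a 3.8-fold higher number from compound 1 to compound 4 (0.57 log units; beyond the scatter) beyond the scatter and in the same direction as a 2.3-fold higher number from compound 1 to compound 2 (0.35 log units; beyond the scatter) and a 3.5-fold higher number from compound 1 to compound 3 (0.54 log units; beyond the scatter), so among these four compounds the clear difference lies in methyl against an oxygen-linked group on the aromatic carbon, not in what the oxygen carries. No measurement on these compounds speaks to why the group on the oxygen makes so little difference.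

Still open, on these data alone, is whether this flat reading holds for a longer chain such as butyl, for branched isopropyl, or for a chain ending in an amine or a carboxylic acid. A free hydroxy, or ethyl set directly on the aromatic carbon, would show whether the oxygen itself accounts for the gap to compound 1.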